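Adding an aromatic methyl to compound 2

This account rests on a few compounds, and the source may have more. Where it says the series, first, only, none or still open, it means among the compounds named here.

compound 1 `COC(=O)NC1=NC(c2cccc(C)c2)CN1` gives 100 mg/kg
compound 2 `COC(=O)NC1=NC(c2ccccc2)CN1C` gives 107 mg/kg
compound 3 `CCN1CC(c2ccccc2)N=C1NC(=O)OC` gives 66 mg/kg

All three numbers come from a functional assay on the whole organism for antagonist activity, with Mus musculus as the target, in the maximal electroshock model (on this read-out lower numbers stand for an effect already at smaller amounts and higher numbers for an effect only at larger amounts of compound), and lie within the scatter of one another, so compound 2 holds no distinct place among them. Compound 4 `COC(=O)NC1=NC(c2cccc(C)c2)CN1C` differs from compound 2 by a single change, methyl in place of hydrogen on an aromatic carbon, meta to a large group: methyl in place of hydrogen on an aromatic carbon. Among the measured compounds shown here, no measured step covers this change directly. For the measured compounds named here, the one measured step, a 1.6-fold lower number from compound 2 to compound 3 (0.21 log units; within the scatter), places a methyl elsewhere, on a saturated chain carbon bound to an amine nitrogen in a ring, so it bears only loosely on this change. Compound 1 also carries a methyl on its aromatic ring, and its 100 mg/kg stays within the scatter of the value for compound 2. No step beyond the scatter is therefore expected in this assay. The estimated step is a 1.1-fold lower number from compound 2 to compound 4 (0.05 log units; within the scatter). For compound 4 the estimated value is 95 mg/kg, with an expected range from 50 mg/kg to 180 mg/kg.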

Compound 4, dose for half-maximal effect: 89 mg/kg
The estimate for compound 4 lay 1.1-fold (0.03 log units) above the measured number; measured number inside the range.
By their numbers in this assay, from the lowest: compounds 3, 4, 1 and 2 (each within the scatter of the next).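

Methyl in place of hydrogen on an aromatic carbon, meta to a large group, now has a direct reading in this assay (a 1.2-fold lower number from compound 2 to compound 4 (0.08 log units; within the scatter)), which the earlier step, with its methyl on a saturated chain carbon, could not supply. With the aromatic methyl already in place, the new pair also reads methyl in place of hydrogen on an amine nitrogen in a ring (a 1.1-fold lower number from compound 1 to compound 4 (0.05 log units; within the scatter)), so neither single methyl change in compound 4 leaves the scatter. No measurement available here accounts for either step.

Going by these compounds, whether a methoxy or trifluoromethyl group on this aromatic carbon would give a step beyond the scatter remains open. So does the effect of a longer chain, such as propyl, on the ring amine nitrogen.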